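Side-chain notes: benzyloxycarbonyl giving way to cyanomethyl

This account rests on a few compounds, and the source may have more. Where it says the series, first, only, none or still open, it means among the compounds named here.

Going by the values given here, compound 2 (`COc1ccc(-c2cc3c(OC)cc(OC)cc3n(CC(=O)OCc3ccccc3)c2=O)cc1`) stands at 10000 nM in a functional assay on A549 cells (Homo sapiens) for cytotoxicity, read by colorimetric assay and MTT assay (a lower number here means a stronger inhibitor, a higher number a weaker inhibitor), on the numbers so far, level with compound 1 (`COc1ccc(-c2cc3c(OC)cc(OC)cc3n(CC#N)c2=O)cc1`) at 10000 nM in the same read-out. Compound 3 (`COc1ccc(-c2cc3c(OC)cc(OC)cc3n(CCC#N)c2=O)cc1`) is the next to be read and carries this change from compound 2: cyanomethyl in place of benzyloxycarbonyl on a saturated chain carbon bound to an aromatic nitrogen. Among the compounds with values here, one measured step bears on it, since it touches the same place on the chain: no change at the digits printed from compound 1 to compound 2 (within the scatter) in this assay and thus no shift beyond the scatter. Within the data shown here, one step is thin support, and the data hold no measured compound with this longer nitrile chain. The estimated step of no change at the digits printed from compound 2 to compound 3 (within the scatter) is expected to stay within the scatter. Compound 3 is expected at 10000 nM with an estimated range of 5000 nM to 20000 nM in this assay when measured.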

Compound 3, half-maximal inhibitory concentration: 10000 nM
Beside the measured number, compound 3's estimate shows no gap at the digits printed; the measured number falls inside the stated range.
By their numbers in this assay, from the lowest: compounds 1, 2 and 3 (each within the scatter of the next).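

In this assay, a third group on the saturated chain carbon bound to an aromatic nitrogen leaves the reading flat: the swap of benzyloxycarbonyl for cyanomethyl, which removes an aromatic ring and brings in a triple bond, gives no change at the digits printed from compound 2 to compound 3 (within the scatter). The two nitrile-bearing side chains also read alike, with cyanomethyl in place of cyano giving no change at the digits printed from compound 1 to compound 3 (within the scatter). No measured evidence accounts for this flat reading.

Going by these compounds alone, the three compounds give no step at this place to build on, so it remains open whether any group there can separate from these values in this assay. A carboxylic acid, a primary amine or a longer nitrile chain on the same core would test that.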